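Deacetylation step and its carry-over to the hydroxy series

This account rests on a few compounds, and the source may have more. Where it says the series, first, only, none or still open, it means among the compounds named here.

Three compounds have been run in an ADME assay on MT4 cells (Homo sapiens) for cytotoxicity, read by MTT assay, with a stated time of 4 days; a higher number here means that more compound is tolerated, a lower number that less compound is tolerated. Compound 1 `CC(=O)Nc1ccc2oc(-c3cccc(C(F)(F)F)c3)cc(=O)c2c1` gives 10000 nM. Its deacetylated counterpart is compound 2 `Nc1ccc2oc(-c3cccc(C(F)(F)F)c3)cc(=O)c2c1`, and in this assay compound 2 gives 138000 nM. The change between them is hydrogen in place of acetyl on a nitrogen on an aromatic ring and it produced a 14-fold higher number from compound 1 to compound 2 (1.14 log units; beyond the scatter). Compound 3 `CC(=O)Nc1ccc2oc(-c3ccccc3)c(O)c(=O)c2c1` gives 64700 nM; its value lies between those of compound 1 and compound 2, and both gaps are beyond the scatter. The difference between the core of compound 1 and the core of compound 3 is not broken down here.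

Compound 4 `Nc1ccc2oc(-c3ccccc3)c(O)c(=O)c2c1` has not yet been measured. It differs from compound 3 by hydrogen in place of acetyl on a nitrogen on an aromatic ring, the same change that turned compound 1 into compound 2, and the place carrying the change reads the same in both pairs. Within this set the change has been seen only once, so its carry-over to the core of compound 3 is an assumption rather than a pattern.

For compound 4 a step of about a 7.0-fold higher number from compound 3 to compound 4 (0.84 log units; beyond the scatter) in this assay is expected, somewhat smaller than the measured 14-fold higher number from compound 1 to compound 2 (1.14 log units; beyond the scatter), because compound 3 already starts from 64700 nM and very high readings in this assay may reach the top of the tested range. The estimate for compound 4 is 450000 nM, with a likely range from 120000 nM to 1500000 nM.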

Compound 4, half-maximal cytotoxic concentration: 217000 nM
For compound 4 the middle estimate is 2.1-fold (0.32 log units) above the measured one, within the range that was stated.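

In this assay the change from acetamido to amino again leaves more compound tolerated on the core of compound 3, with a 3.4-fold higher number from compound 3 to compound 4 (0.53 log units; beyond the scatter), so the direction of the step is the same on both cores shown. The size of the step does not carry over from one core to the other: the same change on two cores in this assay, a 14-fold higher number (1.14 log units; beyond the scatter) from compound 1 to compound 2 and a 3.4-fold higher number (0.53 log units; beyond the scatter) from compound 3 to compound 4, 4.1-fold (0.61 log units) apart, beyond the scatter of two such steps. Two pairs show only that the direction held and the size shifted on these two cores; they give no rule for other cores, and they do not show which of the differences between the core of compound 1 and the core of compound 3 goes with the smaller step.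

Open, as far as these compounds go, is whether the direction and size of the step hold when the nitrogen carries a group other than acetyl or hydrogen, such as a longer acyl chain or a methanesulfonyl group. Also open, from the compounds shown here alone, is how far the step depends on the trifluoromethyl group or on the hydroxyl group taken singly, a question that would need the acetamido and amino pair on a core differing from the core of compound 1 or the core of compound 3 in one place only.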